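Methylpiperazine for piperidine on a hydroxyphenyl core

This account rests on a few compounds, and the source may have more. Where it says the series, first, only, none or still open, it means among the compounds named here.

Three measured compounds frame this account. Compound 1 `CN1CCN(c2nc(-c3cccc(Cl)c3)nc3c2ncn3C)CC1` gives 38.3% in an assay on cells for displacement of a labelled ligand from adenosine receptor A3 (Homo sapiens), read by scintillation counting and radioligand binding, with a stated time of 180 min, tested at 10 uM; on this read-out higher numbers stand for more inhibition at the one concentration tested (going by the name of the read-out) and lower numbers for less inhibition. Compound 2 `Cn1cnc2c(N3CCCCC3)nc(-c3cccc(Cl)c3)nc21` gives 6.1% in this assay. Compound 3 `Oc1ccc(-c2nc(N3CCCCC3)c3nc[nH]c3n2)cc1` reaches the limit of this assay, reported as > 80%, which is a limit and not a number.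

The step from compound 2 to compound 1 is a number 32.2 percentage points higher from compound 2 to compound 1 (beyond the scatter), and the structural change behind it is 4-methylpiperazin-1-yl in place of piperidin-1-yl on an aromatic carbon. How the core of compound 3 differs from the core of compound 2 is not broken down here; the two differ in more than one place.

Compound 4 `CN1CCN(c2nc(-c3ccc(O)cc3)nc3[nH]cnc23)CC1` has not been measured. It differs from compound 3 by 4-methylpiperazin-1-yl in place of piperidin-1-yl on an aromatic carbon. Within the data shown here, this is the same kind of change as the one from compound 2 to compound 1, though not the same: the place is meta to a 4-hydroxyphenyl group in compound 4, where it was meta to a 3-chlorophenyl group in compound 1.

Compound 4 is expected to give about 85% in this assay. The expected range for compound 4 runs from 60% to 97%. The expected step is a step that the limit leaves unreadable from compound 3 to compound 4. That expectation rests on compound 3 already sitting at the limit of > 80% in this assay, at which 1 of the 3 values shown sits, and on compound 1 having gained a number 32.2 percentage points higher from compound 2 to compound 1 (beyond the scatter) from the same kind of change, so that a fall is not anticipated, though a value reported only as a limit is likely.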

Compound 4, a percentage reported as inhibition, at one concentration (the size of the read-out at that concentration, not a potency): 48%
Compound 4: the middle estimate sits 37 percentage points above what was measured; the measured number lies below the stated range.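

In this assay, putting 4-methylpiperazin-1-yl in place of piperidin-1-yl on the core of compound 3 gives a number at least 32 percentage points lower from compound 3 to compound 4 (beyond the scatter), so a change that raised the read-out on one core lowers it on the other, and the two steps do not agree: the same change on two cores in this assay, a number 32.2 percentage points higher (beyond the scatter) from compound 2 to compound 1 and a number at least 32 percentage points lower (beyond the scatter) from compound 3 to compound 4, at least 64.2 percentage points apart, beyond the scatter of two such steps

Compound 3 is recorded as > 80%, which is a limit and not a number. Among these compounds, what this shows is that, within these two pairs, the step measured on one core does not carry over to the other, even in its direction; it does not show which difference between the cores sets that direction, as they differ in more than one place and each core supplies only a single pair.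

Left open is whether the reversal follows the 3-chlorophenyl group, the 4-hydroxyphenyl group or another difference between the cores, which a pair of cores differing in one place alone could separate. Also open, as far as these compounds go, is how other groups in the same place would behave on either core, such as morpholin-4-yl, an unsubstituted piperazin-1-yl or an open-chain dimethylamino group.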